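Swapping the charged ring at the chain end, second instance

The source may report more compounds than this note shows. Statements on the series, on what has been measured and on what is new or still open speak of the compounds shown alone.

Compound 1 `CN(C)c1ccc2c(=O)c(C(=O)Nc3cc(F)cc(F)c3)cn(-c3ccc(OCCCCCCC[N+]45CCN(CC4)CC5)c(Cl)c3)c2n1` and compound 3 `CN(C)c1ccc2c(=O)c(C(=O)Nc3cc(F)cc(F)c3)cn(-c3ccc(OCCCCCCC[N+]4(C)CCCC4)c(Cl)c3)c2n1` share one core and differ only in a group of 6 heavy atoms (5 carbon, 1 nitrogen; one five-membered non-aromatic ring with 1 hetero atom) in place of a group of 8 heavy atoms (6 carbon, 2 nitrogen; 2 six-membered non-aromatic rings with 2 hetero atoms each), on a saturated chain carbon, seven bonds along the chain from an oxygen on an aromatic ring. In an assay on LX2 cells for inhibition of COL1A1 promoter (Homo sapiens), read by a luciferase reporter, with a stated time of 24 h, tested at 50 uM (a lower number here means a weaker effect, a higher number a stronger effect of the compound at the concentration tested), compound 1 gives 20.5%, while compound 3 gives 2.59%, so the change produced a number 17.9 percentage points lower from compound 1 to compound 3 (beyond the scatter). Compound 2 `Cc1cc(OCCCCCCC[N+]23CCN(CC2)CC3)cc(-n2cc(C(=O)Nc3cc(F)cc(F)c3)c(=O)c3ccc(N(C)C)nc32)c1` carries a different core; how it differs from compound 1 is not broken down here. In this assay compound 2 gives 5.52%. Compound 4 `Cc1cc(OCCCCCCC[N+]2(C)CCCC2)cc(-n2cc(C(=O)Nc3cc(F)cc(F)c3)c(=O)c3ccc(N(C)C)nc32)c1` has not been measured; it differs from compound 2 by a group of 6 heavy atoms (5 carbon, 1 nitrogen; one five-membered non-aromatic ring with 1 hetero atom) in place of a group of 8 heavy atoms (6 carbon, 2 nitrogen; 2 six-membered non-aromatic rings with 2 hetero atoms each), on a saturated chain carbon, seven bonds along the chain from an oxygen on an aromatic ring, the same change as in the measured pair. Because the earlier step was a number 17.9 percentage points lower from compound 1 to compound 3 (beyond the scatter), and because compound 2 starts from only 5.52%, the step is expected to be about a number 5.5 percentage points lower from compound 2 to compound 4 (within the scatter), limited by the low starting point. Compound 4 is therefore expected to reach roughly 0%, between -10% and 10%.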

Compound 4, a percentage reported as inhibition, at one concentration (the size of the read-out at that concentration, not a potency): 35.4%
Compound 4: middle estimate off by 35.4 percentage points, on the low side, and the stated range ends below it.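

In this assay, putting the group of 6 heavy atoms in place of the group of 8 heavy atoms at the chain end gave a number 29.9 percentage points higher from compound 2 to compound 4 (beyond the scatter), so the change did not carry its direction over from the core of compound 1 to the core of compound 2: the same change on two cores in this assay, a number 17.9 percentage points lower (beyond the scatter) from compound 1 to compound 3 and a number 29.9 percentage points higher (beyond the scatter) from compound 2 to compound 4, 47.8 percentage points apart, beyond the scatter of two such steps

The outcome of this swap therefore depends on the core it sits on, at least in these two pairs. The pairs do not show which difference between the two cores matters, and they give no rule for any further core.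

Still open, going by these compounds, is how either core responds to other charged chain ends, such as a trimethylammonium or a piperidinium group. Also open, on these data alone, is whether a shorter or longer chain would give the same reversal.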